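This account rests on a few compounds, and the source may have more. Where it says the series, first, only, none or still open, it means among the compounds named here.

Measured so far:
- compound 1 `N=C(NS(=O)(=O)c1cccc(Cl)c1)N1CCN(c2cc3c(cc2F)c(=O)c(C(=O)O)cn3C2CC2)CC1`: 71 nM
- compound 2 `N=C(NS(=O)(=O)c1ccc(Cl)cc1)N1CCN(c2cc3c(cc2F)c(=O)c(C(=O)O)cn3C2CC2)CC1`: 71 nM

In a functional assay on A549 cells (Homo sapiens) for antiproliferative activity, read by MTT assay, with a stated time of 72 h (a lower number here means a stronger inhibitor, a higher number a weaker inhibitor), compound 2 stands level with compound 1, with compound 2 at 71 nM. Next is compound 3 `N=C(NS(=O)(=O)c1ccccc1C(F)(F)F)N1CCN(c2cc3c(cc2F)c(=O)c(C(=O)O)cn3C2CC2)CC1`, with 2-(trifluoromethyl)phenyl in place of 4-chlorophenyl on a sulfonyl sulfur.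

Within the data shown here, only one measured step bears on this change. It sits at the same sulfonyl sulfur and exchanges 3-chlorophenyl for 4-chlorophenyl: no change at the digits printed from compound 1 to compound 2 (within the scatter), within the scatter. Among the measured compounds shown here, no measured compound carries a trifluoromethyl group, so this evidence is thin and gives no firm direction. A small loss is allowed for, given the new group. In this assay, the expected change is a 1.3-fold higher number from compound 2 to compound 3 (0.10 log units; within the scatter), which is not beyond the scatter. The estimate for compound 3 is 90 nM, with an expected range of 30 nM to 270 nM.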

Compound 3, half-maximal inhibitory concentration: 71 nM
Compound 3: middle estimate off by 1.3-fold (0.10 log units), on the high side; measured number inside the range.
By their numbers in this assay, from the lowest: compounds 1, 2 and 3 (each within the scatter of the next).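

In this assay, 2-(trifluoromethyl)phenyl in place of 4-chlorophenyl on the sulfonyl sulfur gives no change at the digits printed from compound 2 to compound 3 (within the scatter), and the same group in place of 3-chlorophenyl gives no change at the digits printed from compound 1 to compound 3 (within the scatter). The earlier step only exchanged one chlorophenyl group for another, whereas here a group of 7 heavy atoms carrying chlorine gives way to one of 10 heavy atoms carrying fluorine, and the number stays level across all three compounds. No separate evidence bears on this result.

The compounds shown have only halogen-bearing phenyl groups at this sulfonyl sulfur, so it remains open whether an amine or a carboxylic acid on the phenyl ring would also leave the number level. The same applies to a plain alkyl chain in place of the phenyl ring.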